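The source may report more compounds than this note shows. Statements on the series, on what has been measured and on what is new or still open speak of the compounds shown alone.

In an assay on H4 cells for inhibition of Fatty-acid amide hydrolase 1 (Homo sapiens) (on this read-out higher numbers stand for weaker inhibition and lower numbers for stronger inhibition), compound 1, `O=C(Nc1ccc(Oc2ccccc2)cc1)Oc1ccccc1F`, gives 1300 nM. Compound 2, `CCOc1ccc(NC(=O)O/N=C/c2ccccc2)cc1`, is built on a different shared core, and in this assay compound 2 gives 81 nM. Compound 3, `CCOc1ccc(NC(=O)O/N=C/c2ccc(F)cc2)cc1`, is the closest relative of compound 2 among the measured compounds, and in this assay compound 3 gives 46 nM. Among the measured compounds shown here, the only single-point step among the measured compounds is a 1.8-fold lower number from compound 2 to compound 3 (0.25 log units; within the scatter). Compound 3 therefore holds the lowest of the three numbers, but it sits close to compound 2, while compound 1 lies far above both.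

Compound 4, `CCCCCCCCCCOc1ccc(NC(=O)O/N=C/c2ccc(F)cc2)cc1`, differs from compound 3 in a single place: octyl in place of hydrogen on a saturated chain carbon, two bonds along the chain from an oxygen on an aromatic ring. For the measured compounds named here, no measured step bears on this change. Going by the values given here, the one step that was measured concerns a fluorine exchange on an aromatic carbon elsewhere in the molecule and tells nothing about lengthening the chain on the ether oxygen. Any expectation for compound 4 therefore rests on the structural change alone and carries wide uncertainty. A step of a 1.5-fold lower number from compound 3 to compound 4 (0.19 log units; within the scatter) is estimated, leaning toward a somewhat lower number. Compound 4 is expected to give 30 nM in this assay, within a range from 8 nM to 110 nM.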

Compound 4, half-maximal inhibitory concentration: 0.25 nM
The estimate for compound 4 lay 120-fold (2.08 log units) above the measured number; measured number outside the range, below it.
By their numbers in this assay, from the lowest: compound 4; then compounds 3 and 2 (each within the scatter of the next); then compound 1.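

Among the compounds shown here, the only earlier step, a 1.8-fold lower number from compound 2 to compound 3 (0.25 log units; within the scatter), stayed within the scatter, so the earlier compounds gave no sign that a single change could move the number by much. In this assay, the position on a saturated chain carbon, two bonds along the chain from an oxygen on an aromatic ring, proves far more responsive: octyl in place of hydrogen, which turns the ethyl group into a decyl group, gives a 180-fold lower number from compound 3 to compound 4 (2.26 log units; beyond the scatter), a large step well beyond the scatter. Nothing available here accounts for the size of this step.

As far as these compounds go, with only ethyl and decyl at this place, the shape of the trend stays unknown: a butyl or hexyl chain could show whether the number falls gradually or sharply as the chain grows, and a chain longer than decyl could show whether the fall continues. From the compounds shown here alone, it also remains open whether a plain carbon chain is needed here, or whether a chain carrying an amine or a carboxylic acid would give a similarly low number.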